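This account rests on a few compounds, and the source may have more. Where it says the series, first, only, none or still open, it means among the compounds named here.

Measured so far in a functional assay on SH-SY5Y cells (Homo sapiens) for cytotoxicity, read by MTT assay, with a stated time of 72 h; on this read-out higher numbers stand for weaker inhibition and lower numbers for stronger inhibition:
compound 1 `O=C1c2c[n+]([O-])c3ccccc3c2C(=O)c2c1c1ccccc1n2Cc1cn([C@H]2C[C@H](O)[C@@H](CO)O2)nn1` gives 620 nM
compound 2 `O=C1c2c[n+]([O-])c3ccccc3c2C(=O)c2c1c1ccccc1n2Cc1cn(CC(O)CO)nn1` gives > 1000 nM

For compound 2 the figure in this assay is a limit of the assay, not a number (the limit of > 1000 nM in this assay, at which 1 of the 2 values shown sits). Compound 2 therefore stands only at that limit among the values shown. Among the measured compounds shown here, the single measured step is an at least 1.6-fold higher number from compound 1 to compound 2 (0.20 log units; that floor lies within the scatter).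

Compound 3 `CC1(C)OC[C@H](Cn2cc(Cn3c4c(c5ccccc53)C(=O)c3c[n+]([O-])c5ccccc5c3C4=O)nn2)O1` differs from compound 2 by 2,2-dimethyl-1,3-dioxolan-4-yl in place of 1,2-dihydroxyethyl on a saturated chain carbon bound to an aromatic nitrogen. For the measured compounds named here, no measured step covers this change, and the step from compound 1 to compound 2 offers no direction beyond the scatter, so compound 2 at its limit is the only anchor. The expected step is a step that the limit leaves unreadable from compound 2 to compound 3, with a real chance that only a limit is returned again. Compound 3 is estimated at 1600 nM, range 600 nM to 4500 nM.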

Compound 3, half-maximal inhibitory concentration: 820 nM
Compound 3: middle estimate off by 2.0-fold (0.29 log units), on the high side, within the range that was stated.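

In this assay, the 2,2-dimethyl-1,3-dioxolan-4-yl group on the saturated chain carbon returns a measured number where 1,2-dihydroxyethyl did not, a change read as an at least 1.2-fold lower number from compound 2 to compound 3 (0.08 log units; that floor lies within the scatter). The true size of this step stays unread because compound 2 sits at a limit of the assay: the limit of > 1000 nM in this assay, at which 1 of the 3 values shown sits. The other comparison reads a 1.3-fold higher number from compound 1 to compound 3 (0.12 log units; within the scatter), so a substituent with 0 hydrogen-bond donors still gives a value level with that of the hydroxylated compound 1.

Going by these compounds, whether an amine or a carboxylic acid on this chain would move the number beyond the scatter stays open. So does the effect of the opposite configuration at the dioxolane stereocentre.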